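A few compounds are considered here, and "the series" means these few. Any claim that something is new, unique, unknown or untested is made for them only; others in the source may bear on it.

Working notes on the series. Compound 1 `O=C(O)COc1ccc(Cl)cc1C#Cc1ccc(CO)cc1F` gives 28 nM in an assay on CHO cells for displacement of a labelled ligand from prostaglandin D2 receptor 2 (Homo sapiens), read by scintillation counting; a higher number here means a weaker inhibitor, a lower number a stronger inhibitor. Compound 2 `Cc1ccc(S(=O)(=O)Cc2ccccc2)cc1C#Cc1cc(Cl)ccc1OCC(=O)O` gives 5 nM in this assay, and compound 3 `Cc1ccc(S(=O)(=O)N2CCN(C)CC2)cc1C#Cc1cc(Cl)ccc1OCC(=O)O` gives 21 nM in this assay. Compound 3 thus holds the second highest of the three numbers: its gap to compound 1 lies within the scatter, whereas the step of a 4.2-fold higher number from compound 2 to compound 3 (0.62 log units; beyond the scatter) lies beyond it. Compound 4 `CCS(=O)(=O)c1ccc(C)c(C#Cc2cc(Cl)ccc2OCC(=O)O)c1` differs from compound 3 by ethyl in place of 4-methylpiperazin-1-yl on a sulfonyl sulfur. Within the data shown here, the only measured step at this position, a 4.2-fold higher number from compound 2 to compound 3 (0.62 log units; beyond the scatter), shows that the group on the sulfonyl sulfur can shift this assay beyond the scatter; no measured step covers ethyl there, so the direction is uncertain. For compound 4 a modest lowering of the number is expected, a step of a 2.1-fold lower number from compound 3 to compound 4 (0.32 log units; beyond the scatter). Compound 4 is estimated at 10 nM, within a range of 4 nM to 30 nM.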

Compound 4, inhibition constant: 8.6 nM
The estimate for compound 4 lay 1.2-fold (0.07 log units) above the measured number; measured number inside the range.
By their numbers in this assay, from the lowest: compounds 2 and 4 (each within the scatter of the next); then compounds 3 and 1 (each within the scatter of the next).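

In this assay, ethyl in place of 4-methylpiperazin-1-yl on the sulfonyl sulfur gives the second measured step at this position (a 2.4-fold lower number from compound 3 to compound 4 (0.39 log units; beyond the scatter)), and this time the number falls. Methyl in place of phenyl on the saturated chain carbon bound to the sulfonyl sulfur (a 1.7-fold higher number from compound 2 to compound 4 (0.24 log units; within the scatter)) leaves compounds 2 and 4 unseparated, so the phenyl ring is not required for a number in this range. No available evidence accounts for either step.

From the compounds shown here alone, how a primary amine, a carboxylic acid or a longer chain such as n-butyl on the sulfonyl sulfur would read remains open.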